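A Fluoro for Trifluoromethyl in Compound 1

The source may hold more compounds than are shown below. What is called first, only, known or untested is meant among the compounds shown, and "the series" means these compounds.

In a functional assay on BT-483 cells (Homo sapiens) for cytotoxicity, read by MTT assay, with a stated time of 24 h (on this read-out higher numbers stand for weaker inhibition and lower numbers for stronger inhibition), compound 1 (`CCNc1cc(-c2ccc(NC(=O)Nc3ccc(C(F)(F)F)cc3)cc2C(F)(F)F)ccn1`) gives 16400 nM and compound 2 (`CCNc1cc(-c2ccc(NC(=O)Nc3c(C)cccc3C)cc2C(F)(F)F)ccn1`) gives 22000 nM, so the two stand level within the scatter. Compound 3 (`CCNc1cc(-c2ccc(NC(=O)Nc3ccc(C(F)(F)F)cc3)cc2F)ccn1`) differs from compound 1 by fluoro in place of trifluoromethyl on an aromatic carbon, with fluoro in place of trifluoromethyl on an aromatic carbon. Among the measured compounds shown here, the only measured step, a 1.3-fold higher number from compound 1 to compound 2 (0.13 log units; within the scatter), concerns the group on an amide-type nitrogen and does not touch this carbon. It offers only indirect guidance, and no change beyond the scatter is expected in either direction. The expected step is a 1.1-fold higher number from compound 1 to compound 3 (0.04 log units; within the scatter). Compound 3 is estimated at 18000 nM, with a range of 7000 nM to 45000 nM.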

Compound 3, half-maximal inhibitory concentration: 26800 nM
For compound 3 the middle estimate is 1.5-fold (0.17 log units) below the measured one; measured number inside the range.
By their numbers in this assay, from the lowest: compounds 1, 2 and 3 (each within the scatter of the next).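

In this assay, fluoro in place of trifluoromethyl on this aromatic carbon, ortho to a 2-(ethylamino)pyridin-4-yl group, gives a 1.6-fold higher number from compound 1 to compound 3 (0.21 log units; within the scatter). Among the compounds shown here, the earlier step touched only the amide-type nitrogen, so this is the first sign that the carbon tolerates this exchange without a change beyond the scatter. No evidence is available that bears on this result. The compounds shown leave open how this carbon would respond to an amine, a methoxy group or a carboxylic acid. They also leave open whether fluoro here would stay level when combined with the 2,6-dimethylphenyl group on the nitrogen.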